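Swapping bromo for methyl on an aromatic carbon

The source may hold more compounds than are shown below. What is called first, only, known or untested is meant among the compounds shown, and "the series" means these compounds.

compound 1 `CCOC(=O)c1cnc2n(c1=O)C(C)CC/C2=N\Nc1ccccc1C(=O)O` gives 100000 nM
compound 2 `CC1CC/C(=N\Nc2cccc(Br)c2)c2ncc(C(=O)O)c(=O)n21` gives 6700 nM
compound 3 `C[C@@H]1CC/C(=N\Nc2ccc(O)cc2)c2ncc(C(=O)O)c(=O)n21` gives 15600 nM

These numbers all come from a functional assay (mast cells) for inhibition, with Rattus norvegicus as the target (a lower number here means that less compound is needed, a higher number that more compound is needed for the effect), where compound 2 stands lowest of the three, with compound 3 (15600 nM) and compound 1 (100000 nM) both higher by more than the scatter. Among the compounds with values here, compound 4 `Cc1cccc(N/N=C2\CCC(C)n3c2ncc(C(=O)O)c3=O)c1` is still unmeasured and differs from compound 2 in one place, with methyl in place of bromo on an aromatic carbon as the only change. Within the data shown here, no measured pair shows this swap, so the expectation is loose: a modest move towards a higher number that may stay within the scatter. The expected step runs a 1.3-fold higher number from compound 2 to compound 4 (0.13 log units; within the scatter) as a rough guess. For compound 4 the estimate is 9000 nM with an expected range from 3500 nM to 23000 nM as its span.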

Compound 4, half-maximal effective concentration: 72900 nM
Compound 4: the middle estimate sits 8.1-fold (0.91 log units) below what was measured; measured number outside the range, above it.
By their numbers in this assay, from the lowest: compound 2; then compound 3; then compounds 4 and 1 (each within the scatter of the next).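

In this assay, swapping bromo for methyl on this aromatic carbon, meta to a large group, is far from a neutral exchange: it brings an 11-fold higher number from compound 2 to compound 4 (1.04 log units; beyond the scatter), even though each group counts one heavy atom. Within the data shown here, the earlier compounds differ in more than one place, so this is the first reading of this position alone, and far less of the 3-bromophenyl compound is needed. Nothing available explains this gap. From the compounds shown here alone, what chloro, methoxy or an amine would do at this position remains open.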